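A few compounds are considered here, and "the series" means these few. Any claim that something is new, unique, unknown or untested is made for them only; others in the source may bear on it.

Measured in an ADME assay on Raji cells (Homo sapiens) for cytotoxicity, read by luminescence, with a stated time of 72 h; on this read-out higher numbers stand for an effect only at larger amounts of compound and lower numbers for an effect already at smaller amounts:

Compound 1 `CCOC(=O)c1c(-c2cccc(OC)c2)[nH]c2cc(C(F)(F)F)ccc2c1=O`: > 21500 nM, a limit
Compound 2 `CCOC(=O)c1c(-c2cccc(OC)c2)[nH]c2cc(SC)ccc2c1=O`: > 21500 nM, a limit
Compound 3 `CCOC(=O)c1c(-c2cccc(OC)c2)[nH]c2cc(F)cc(F)c2c1=O`: > 21500 nM, a limit

The picture so far is the limit of > 21500 nM in this assay, at which 3 of the 3 values shown sit. None of these results is an exact number, so the three compounds cannot be ranked against one another.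

Compound 3 stands at > 21500 nM, which is a limit.

Compound 4 `CCOC(=O)c1c(-c2cccc(OC(F)(F)F)c2)[nH]c2cc(F)cc(F)c2c1=O` differs from compound 3 in a single place: trifluoromethyl in place of methyl on an oxygen on an aromatic ring. In plain terms, the change is methoxy to trifluoromethoxy.

Going by the values given here, the only measured step is a step that the two limits leave unreadable from compound 1 to compound 2. It is a different change from this one and has no readable size, so it offers nothing to carry over. Among the compounds with values here, the consistent limits are the only guide, and no step beyond the scatter is expected in this assay. Another limit is the most likely report.

If a number does appear, compound 4 is estimated at 25000 nM, with an expected range from 12000 nM to 50000 nM.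

The expected change is a step that the limit leaves unreadable from compound 3 to compound 4.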

Compound 4, half-maximal effective concentration: > 21500 nM
Compound 4 was reported as a limit; the forecaster's own chance of this, stated with the estimate: 85%; the middle value lies beyond the limit too.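

Compound 3 and compound 4 are both reported only as limits, so the change from methoxy to trifluoromethoxy gives no step that can be read: the limit of > 21500 nM in this assay, at which 4 of the 4 values shown sit.

The compounds shown leave open at what concentration, if any, each one harms these cells, and whether any single change shifts that.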